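A few compounds are considered here, and "the series" means these few. Any claim that something is new, unique, unknown or untested is made for them only; others in the source may bear on it.

Compound 1 `C=Cc1ccc(-c2cc(C)c3ncc(CSCCc4ccccc4)n3c2)cc1` is the starting point of this step. Among the measured compounds shown here, in an ADME assay on HEL cells (Homo sapiens) for cytotoxicity, with a stated time of 3 days (on this read-out lower numbers stand for higher toxicity in this test and higher numbers for lower toxicity in this test), compound 1 gives 14 ug/mL, the lowest of the three numbers measured so far. Compound 2 `Cc1cc(-c2ccc3[nH]ccc3c2)cn2c(CSCCc3ccccc3)cnc12` gives 26 ug/mL and compound 3 `Cc1cc(N2CCN(C)CC2)cn2c(CSCCc3ccccc3)cnc12` gives 32 ug/mL. The step of a 1.9-fold higher number from compound 1 to compound 2 (0.27 log units; within the scatter) and the step of a 1.2-fold higher number from compound 2 to compound 3 (0.09 log units; within the scatter) are both within the scatter, while the step of a 2.3-fold higher number from compound 1 to compound 3 (0.36 log units; beyond the scatter) is a modest rise beyond it. Compound 4 `Cc1cc(C#N)cn2c(CSCCc3ccccc3)cnc12` has not yet been measured; its difference from compound 1 is cyano in place of 4-vinylphenyl on an aromatic carbon. Both measured steps from compound 1 swap the same 4-vinylphenyl group for a different group, and both move the number upward, one within and one just beyond the scatter. By analogy, the expected outcome for compound 4 is a small to modest rise in this assay, estimated as a 2.1-fold higher number from compound 1 to compound 4 (0.33 log units; beyond the scatter). Compound 4 is therefore expected to fall near 30 ug/mL, with a range of 14 ug/mL to 65 ug/mL.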

Compound 4, half-maximal cytotoxic concentration: 14 ug/mL
The estimate for compound 4 lay 2.1-fold (0.33 log units) above the measured number, within the range that was stated.
By their numbers in this assay, from the lowest: compounds 1, 4, 2 and 3 (each within the scatter of the next, the first and the last beyond it).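

At this place, on an aromatic carbon para to a fused ring, cyano brings no rise in this assay: the swap for 4-vinylphenyl gives no change at the digits printed from compound 1 to compound 4 (within the scatter), so the upward movement seen with the two earlier replacements does not hold for every group entering here. The comparison with the other groups gives a 2.3-fold lower number from compound 3 to compound 4 (0.36 log units; beyond the scatter) and a 1.9-fold lower number from compound 2 to compound 4 (0.27 log units; within the scatter), which leaves only 4-methylpiperazin-1-yl separated from cyano, while cyano, with 2 heavy atoms and no ring, matches 4-vinylphenyl, with 8 heavy atoms and one ring, so heavy-atom count alone does not order these compounds. Nothing available accounts for these differences.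

The compounds shown leave open whether a primary amine, a carboxylic acid or an amide at this place would stand apart from cyano as 4-methylpiperazin-1-yl does. On these data alone, it also remains open whether cyano would give the same number with an ethyl group in place of the methyl group.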